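Swapping an Amide for a Carbamate: What to Expect

The source may hold more compounds than are shown below. What is called first, only, known or untested is meant among the compounds shown, and "the series" means these compounds.

Measured so far in an assay on CHO-K1 cells for displacement of a labelled ligand from prostaglandin E2 receptor EP1 subtype (Homo sapiens); on this read-out higher numbers stand for weaker inhibition and lower numbers for stronger inhibition:
compound 1 `Cc1cc(C(=O)O)nn1Cc1cc(Br)ccc1OCc1ccccc1`, 6.31 nM
compound 2 `Cc1cc(C(=O)O)nn1C(C)c1cc(Cl)ccc1OCc1ccccc1`, 10 nM
compound 3 `Cc1cc(C(=O)NCc2ccncc2)nn1Cc1cc(Cl)ccc1OCc1ccccc1`, 79.4 nM

Among these three, compound 3 gives the highest number, and its distance from compound 2 and from compound 1 lies beyond the usual scatter, so it is the weakest of the measured set. Compound 4 `Cc1cc(NC(=O)OCc2ccccn2)nn1Cc1cc(Cl)ccc1OCc1ccccc1` keeps everything else of compound 3 and alters one group: (((pyridin-2-yl)methoxy)carbonyl)amino in place of ((pyridin-4-yl)methyl)carbamoyl on an aromatic carbon. Within the data shown here, no pair of measured compounds shows this kind of change, so the expectation rests on compound 3 alone and on the fact that the incoming group is of similar size to the departing one, carrying a pyridin-2-yl ring where a pyridin-4-yl ring stood. The expected step is a 1.9-fold higher number from compound 3 to compound 4 (0.28 log units; within the scatter), small and toward a higher number, quite possibly not beyond the scatter. Compound 4 is therefore estimated at 150 nM, with a range from 30 nM to 800 nM.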

Compound 4, half-maximal inhibitory concentration: 79.4 nM
Estimate against measurement, compound 4: 1.9-fold (0.28 log units) above, within the range that was stated.
By their numbers in this assay, from the lowest: compounds 1 and 2 (each within the scatter of the next); then compounds 3 and 4 (each within the scatter of the next).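

In this assay, putting (((pyridin-2-yl)methoxy)carbonyl)amino in place of ((pyridin-4-yl)methyl)carbamoyl on this aromatic carbon gives no change at the digits printed from compound 3 to compound 4 (within the scatter). This position of the five-membered aromatic ring therefore accepts a carbamate attached through its nitrogen as readily as an amide attached through its carbonyl carbon, at least with these pyridine-bearing groups. The step alters the linker and the pyridine attachment point together, so it cannot show whether each change is silent alone or whether two opposing effects cancel, and nothing at hand explains why the two groups read alike.

From the compounds shown here alone, it remains open whether a simple phenyl ring in place of the pyridine would read the same. A longer chain between the linker and the ring is equally unresolved.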